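Naphthyl for Bromophenyl in a Thiourea Ether Series

The source may report more compounds than this note shows. Statements on the series, on what has been measured and on what is new or still open speak of the compounds shown alone.

Compound 1, `S=C(N/N=C/c1ccc(Oc2ccc3ccccc3c2)cc1)Nc1ccccc1`, gives 6.07 in a physicochemical assay for lipophilicity, in phosphate buffer, measured as octanol-water partition, with a stated time of 24 h; on this read-out higher numbers stand for higher lipophilicity and lower numbers for lower lipophilicity.
Compound 2, `Fc1ccc(NC(=S)N/N=C/c2ccc(Oc3ccc(F)cc3)cc2)cc1`, gives 5.19 in this assay.
Compound 3, `Fc1ccc(NC(=S)N/N=C/c2ccc(Oc3ccc(Br)cc3)cc2)cc1`, gives 5.88 in this assay.

Compound 3 stands second of the three values. Its nearest neighbour is compound 1, whose value lies somewhat higher, though the gap falls within the scatter of the measurement. Compound 2 sits furthest away, with the only step among these three that clearly exceeds the scatter: a number 0.69 log units higher from compound 2 to compound 3 (beyond the scatter).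

Compound 4, `Fc1ccc(NC(=S)N/N=C/c2ccc(Oc3ccc4ccccc4c3)cc2)cc1`, has not yet been measured. It differs from compound 3 in a single place: naphthalen-2-yl in place of 4-bromophenyl on an oxygen on an aromatic ring. Among the measured compounds shown here, no measured pair shows exactly this exchange. For the measured compounds named here, the one measured step, from compound 2 to compound 3, concerns a different exchange on the same ring and says only that a heavier halogen on that ring raised the value by a modest amount. Compound 1, which carries the naphthalen-2-yl group but lacks the fluoro on the other ring, shows a value slightly above that of compound 3, within the scatter.

On this basis compound 4 is expected to move upward by a number 0.32 log units higher from compound 3 to compound 4 (beyond the scatter), a step near the edge of the scatter. The estimate for compound 4 is 6.2, expected to fall between 5.8 and 6.7.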

Compound 4, partition coefficient: 6.2
Compound 4: middle estimate and measured number agree at the digits printed, within the range that was stated.
By their numbers in this assay, from the lowest: compound 2; then compounds 3, 1 and 4 (each within the scatter of the next, the first and the last beyond it).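

At this position, on an oxygen on an aromatic ring, the earlier compounds had shown only one halogen exchanged for another; in this assay, naphthalen-2-yl in place of 4-bromophenyl, with 10 heavy atoms entering for 7 and two six-membered aromatic rings of carbon only for one, gives a number 0.32 log units higher from compound 3 to compound 4 (beyond the scatter) and thus shows that a change of ring system at this place also moves the number. Naphthalen-2-yl in place of 4-fluorophenyl gives a number 1.01 log units higher from compound 2 to compound 4 (beyond the scatter) in this assay, the only large step among the compounds shown, and it spans the bromo step as well. Among the compounds shown here, the fluoro in place of hydrogen on an aromatic carbon, read here for the first time, gives a number 0.13 log units higher from compound 1 to compound 4 (within the scatter) in the same read-out, so that exchange does not separate these two compounds.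

Nothing among the available data accounts for the size of these steps. From the compounds shown here alone, whether a cyclohexyl group on the same oxygen, or an amine or a carboxylic acid carried on the naphthalen-2-yl group, would keep the number at this level remains open.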